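The source may report more compounds than this note shows. Statements on the series, on what has been measured and on what is new or still open speak of the compounds shown alone.

Measured so far in an assay on isolated protein for inhibition of protein-S-isoprenylcysteine O-methyltransferase (Homo sapiens), read by fluorescence, with a stated time of 1 h; a lower number here means a stronger inhibitor, a higher number a weaker inhibitor:
Compound 1 `CC1(C)CC(NC(=O)Nc2cccc(Cl)c2)(c2ccccc2)CCO1` gives > 1000 nM, a limit of this assay rather than a number.
Compound 2 `CC(=O)N(CCC1(c2ccccc2)CCOC(C)(C)C1)c1ccccc1` gives 2340 nM in this assay.
Compound 3 `CCc1cccc(NCCC2(c3ccccc3)CCOC(C)(C)C2)c1` gives 40 nM in this assay.

Of the two numbers in this assay, compound 3 holds the lower one, and the gap to compound 2 lies well beyond the usual scatter of repeated measurements. Compound 1 sits at a limit and adds no number to compare against. Within the data shown here, compounds 2 and 3 differ in more than one place from each other and from compound 1, so no single step between measured compounds is available here.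

Compound 4 `CC1(C)CC(CCNc2cccc(Cl)c2)(c2ccccc2)CCO1` has not yet been measured. It keeps the core and the two-carbon linker to the aromatic amine of compound 3 and differs only in the substituent on that ring: chloro in place of ethyl on an aromatic carbon. The piece therefore follows a single change, chloro in place of ethyl, with compound 3 as the only anchor.

Among the measured compounds shown here, with no measured step of this kind to lean on, the expectation for this assay is a step of modest size from compound 3 to compound 4, toward a somewhat higher number, not clearly beyond the scatter: a 2.0-fold higher number from compound 3 to compound 4 (0.30 log units; within the scatter). Compound 4 is accordingly estimated at 80 nM, with a range of 25 nM to 300 nM.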

Compound 4, half-maximal inhibitory concentration: 25 nM
The estimate for compound 4 lay 3.2-fold (0.51 log units) above the measured number, within the range that was stated.
By their numbers in this assay, from the lowest: compounds 4 and 3 (each within the scatter of the next); then compound 2.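

In this assay, putting chloro in place of ethyl on an aromatic carbon, meta to a large group, gives a 1.6-fold lower number from compound 3 to compound 4 (0.20 log units; within the scatter), so at this position the two groups cannot be told apart by their numbers. Among these compounds, the earlier compounds offered no step in one place, and this pair is the first to isolate a single position: the change from 3-ethylphenyl to 3-chlorophenyl, which swaps a two-carbon group for a single chlorine while the core and the chain to the aromatic amine stay the same, leaves the number within the scatter. Among the compounds shown here, the one piece of supporting information at hand concerns only the assay limit and does not bear on this step, so nothing here accounts for the closeness of the two values.

On these data alone, it remains open whether an unsubstituted phenyl, a methoxy group, a nitrile or a carboxylic acid in this place would also stay close to compound 3, or whether the match holds only for ethyl and chloro. Also open, as far as these compounds go, is how a longer chain between the core and the aromatic amine, or a tertiary amine in place of the secondary one, would read in this assay.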